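Second Chloro on the Purine Core of a Benzyl Chloride

This account rests on a few compounds, and the source may have more. Where it says the series, first, only, none or still open, it means among the compounds named here.

Compound 1 `ClCc1ccc(Cn2cnc3c(Cl)ncnc32)cc1` is the only compound among those shown with a numeric result: in a functional assay on CAKI-1 cells (Homo sapiens) for cytotoxicity, read by sulforhodamine B assay, with a stated time of 48 h (on this read-out higher numbers stand for lower toxicity in this test and lower numbers for higher toxicity in this test), compound 1 gives 2390 nM. Compound 2 `ClCc1cccc(Cn2cnc3ncnc(Cl)c32)c1` gives only a limit in this assay, namely > 100000 nM, and that limit is where one of the two values shown sits (the limit of > 100000 nM in this assay, at which 1 of the 2 values shown sits). Compound 3 `ClCc1ccc(Cn2cnc3c(Cl)nc(Cl)nc32)cc1` has not yet been measured in this assay. It differs from compound 1 by chloro in place of hydrogen on an aromatic carbon, which is chloro in place of hydrogen on an aromatic carbon. Among the measured compounds shown here, no step linking two measured compounds is available to calibrate this change. The step expected from compound 1 to compound 3 in this assay is a 1.6-fold lower number from compound 1 to compound 3 (0.20 log units; within the scatter), a small move toward greater toxicity that may not exceed the usual scatter. Compound 3 is therefore expected to give about 1500 nM in this assay, within a range from 500 nM to 6000 nM.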

Compound 3, concentration lethal to 50% of the cells: 46800 nM
For compound 3 the middle estimate is 31-fold (1.49 log units) below the measured one; measured number above the stated range.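

In this assay the chloro entering on the aromatic carbon between two ring nitrogen atoms brings a 20-fold higher number from compound 1 to compound 3 (1.29 log units; beyond the scatter) and so moves the compound toward lower toxicity in this test. Among the compounds shown here, this is the first step between two measured compounds that differ in one place, and it shows that this position does not tolerate the change silently: a single chlorine in place of hydrogen is enough to shift the read-out well beyond the scatter. Nothing shown here accounts for the step.

From the compounds shown here alone, whether an amine, a methoxy group or a longer chain at this same position would move the number in the same direction remains open. So does whether chloro in place of hydrogen here would have a similar effect on any compound other than compound 1.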